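Compound 3 at the Cytotoxicity Limit, Acetoxy Added

The source may report more compounds than this note shows. Statements on the series, on what has been measured and on what is new or still open speak of the compounds shown alone.

Compound 1 `O=C(c1ccc(Cl)cc1)c1ccn(-c2ccc3c(c2)B(O)OC3)c1`: in an ADME assay on L929 cells (Mus musculus) for cytotoxicity, read by resazurin assay, with a stated time of 72 h (a higher number here means a weaker inhibitor, a lower number a stronger inhibitor), compound 1 gives > 10 ug/mL, a limit of the assay.
Compound 2 `O=C(c1cccc(Cl)c1)c1ccn(-c2ccc3c(c2)B(O)OC3)c1`: compound 2 gives > 10 ug/mL, again a limit.
Compound 3 `Cc1ccc(C(=O)c2ccn(-c3ccc4c(c3)B(O)OC4)c2)cc1`: compound 3 gives > 10 ug/mL, also a limit.

Compound 3 therefore stands where every measured value sits, namely (the limit of > 10 ug/mL in this assay, at which 3 of the 3 values shown sit), and no number separates it from compound 1 or compound 2. The measured steps, a step that the two limits leave unreadable from compound 1 to compound 3, a step that the two limits leave unreadable from compound 2 to compound 3 and a step that the two limits leave unreadable from compound 1 to compound 2, cannot be read at all; each ends at a limit. Compound 4 `CC(=O)OCc1ccc(C(=O)c2ccn(-c3ccc4c(c3)B(O)OC4)c2)cc1` carries acetoxy in place of hydrogen on a saturated chain carbon bound to an aromatic carbon. For the measured compounds named here, no measured step involves an acetoxy group, so the expectation rests on the limits alone. Compound 4 is expected to show a step that the limit leaves unreadable from compound 3 to compound 4, nothing beyond the scatter. Compound 4 is estimated at 20 ug/mL, ranging from 7 ug/mL to 60 ug/mL, most likely reported as a limit once more.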

Compound 4, half-maximal inhibitory concentration: 10 ug/mL
Estimate against measurement, compound 4: 2.0-fold (0.30 log units) above; low and high end bracket the measured number.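

In this assay, for the compounds shown here, the acetoxy group on a saturated chain carbon bound to an aromatic carbon gives a number no higher from compound 3 to compound 4 (the limit leaves the size open) and acetoxymethyl in place of chloro gives a number no higher from compound 1 to compound 4 (the limit leaves the size open) for the first time with a plain number at one end. Neither step can be sized, since the other end of each is a limit. The series still sits mostly at one reading: the limit of > 10 ug/mL in this assay, at which 3 of the 4 values shown sit.

On these data alone, what a hydroxymethyl group, a carboxylic acid or an amine would give on this carbon stays open. So does whether a longer chain would push the number lower.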